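Amide aryl variation on the shared core: compound 4

The compounds below may be only part of what the source reports. "The series", "measured", "known", "first", "only" and "open" are said of these compounds alone.

Compound 1 `O=C(Nc1cccc(-c2oc3cc(-c4ccc(F)cc4)ccc3c(=O)c2O)c1)c1ccc(F)cc1F` carries a 2,4-difluorophenyl group on the carbonyl carbon of the amide attached to the shared core. In a functional assay on HepG2 cells (Homo sapiens) for antiproliferative activity, read by CCK-8 assay, with a stated time of 72 h (on this read-out higher numbers stand for weaker inhibition and lower numbers for stronger inhibition), compound 1 gives 26400 nM, the second highest of the three measured numbers. Compound 2 `Cc1cc(C(=O)Nc2cccc(-c3oc4cc(-c5ccc(F)cc5)ccc4c(=O)c3O)c2)ccc1F` gives 9540 nM in this assay, and the step is a 2.8-fold lower number from compound 1 to compound 2 (0.44 log units; beyond the scatter). Compound 3 `O=C(Nc1cccc(-c2oc3cc(-c4ccc(F)cc4)ccc3c(=O)c2O)c1)c1ccc(-c2ccccc2)cc1` gives 88500 nM in this assay, with a 3.4-fold higher number from compound 1 to compound 3 (0.53 log units; beyond the scatter); between compounds 2 and 3 the step is a 9.3-fold higher number from compound 2 to compound 3 (0.97 log units; beyond the scatter).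

Compound 4 `CCCc1ccc(C(=O)Nc2cccc(-c3oc4cc(-c5ccc(F)cc5)ccc4c(=O)c3O)c2)cc1` differs from compound 1 in one place: 4-propylphenyl in place of 2,4-difluorophenyl on a carbonyl carbon.

Both measured steps from compound 1 bear on this change; each replaces the same 2,4-difluorophenyl with another single-ring group on the carbonyl carbon. They run in opposite directions: the 4-fluoro-3-methylphenyl group brought a modest lower number, the 4-phenylphenyl group a modest higher number. With only these two opposed steps, no clear direction for the 4-propylphenyl group can be read off, and the expected step of a 1.1-fold lower number from compound 1 to compound 4 (0.02 log units; within the scatter) is none beyond the scatter, though the uncertainty is wide. For compound 4 in this assay the estimate is 25000 nM, with a range from 7000 nM to 90000 nM.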

Compound 4, half-maximal inhibitory concentration: 51500 nM
Estimate against measurement, compound 4: 2.1-fold (0.31 log units) below, and the stated range covers the measured number.
By their numbers in this assay, from the lowest: compound 2; then compounds 1, 4 and 3 (each within the scatter of the next, the first and the last beyond it).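

Compound 4 sits within the scatter of two groups that lie beyond the scatter of each other, with a 2.0-fold higher number from compound 1 to compound 4 (0.29 log units; within the scatter) and a 1.7-fold lower number from compound 3 to compound 4 (0.24 log units; within the scatter), so in this assay the 4-propylphenyl group cannot be ordered against either the 2,4-difluorophenyl or the 4-phenylphenyl group on this carbonyl carbon. Compound 4 stays clearly apart only from the 4-fluoro-3-methylphenyl amide, with a 5.4-fold higher number from compound 2 to compound 4 (0.73 log units; beyond the scatter), and compound 2 now has steps beyond the scatter to all three other amides, which leaves the 4-fluoro-3-methylphenyl group alone at the low end of this set of four; compounds 1, 3 and 4 do not share that lower number.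

No measurement at hand accounts for any of these steps.

Still open, from the compounds shown here alone, is whether the lower number of compound 2 follows the methyl, the fluorine or the pair, which a phenyl carrying only a methyl or only a fluorine on this carbonyl carbon would help to separate. Also open is how a longer chain than propyl, an amine or a carboxylic acid on the same aryl ring would read in this assay series, since the four groups shown carry only fluorine and carbon substituents.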